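The compounds below may be only part of what the source reports. "The series", "measured", "known", "first", "only" and "open" are said of these compounds alone.

Going by the values given here, in a functional assay on NCI-H460 cells (Homo sapiens) for inhibition, with a stated time of 72 h (on this read-out lower numbers stand for stronger inhibition and higher numbers for weaker inhibition), compound 2 (`COc1ccc(S(=O)(=O)N2CCc3cccc(-c4ccc(F)c(F)c4)c32)cc1`) gives 46 nM and stands lowest of the three numbers so far. Compound 1 (`COc1ccc(S(=O)(=O)N2CCc3cccc(-c4ccc(F)nc4)c32)cc1`) gives 135 nM on the same read-out, and compound 3 (`COc1ccc(S(=O)(=O)N2CCc3cccc(-c4cc(OC)c(OC)c(OC)c4)c32)cc1`) gives 6340 nM on it. Compound 4 (`COc1ccc(-c2cccc3c2N(S(=O)(=O)c2ccc(OC)cc2)CC3)cc1`) carries 4-methoxyphenyl in place of 3,4-difluorophenyl on an aromatic carbon. Among the compounds with values here, the one measured step at this place is modest (a 2.9-fold lower number from compound 1 to compound 2 (0.47 log units; beyond the scatter)). Compound 3, at 6340 nM with its methoxy-bearing aryl group, shows that a change here can raise the number far more, but it carries more methoxy groups than compound 4. A modest rise in this assay is therefore expected (a 2.4-fold higher number from compound 2 to compound 4 (0.38 log units; beyond the scatter)) from the present data. The estimate for compound 4 is 110 nM within an expected range of 25 nM to 600 nM for now.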

Compound 4, half-maximal inhibitory concentration: 302 nM
Estimate against measurement, compound 4: 2.7-fold (0.44 log units) below; the measured number falls inside the stated range.
By their numbers in this assay, from the lowest: compound 2; then compound 1; then compound 4; then compound 3.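

Replacing 3,4-difluorophenyl with 4-methoxyphenyl at this aromatic carbon gives a 6.6-fold higher number from compound 2 to compound 4 (0.82 log units; beyond the scatter) in this assay and shows that a single methoxy group on the phenyl ring is enough to raise the number. Replacing 6-fluoropyridin-3-yl with the same 4-methoxyphenyl gives a 2.2-fold higher number from compound 1 to compound 4 (0.35 log units; beyond the scatter) and places this group above both fluorinated groups, yet well short of the trimethoxyphenyl of compound 3 at 6340 nM in this series. Nothing at hand explains these steps.

Open, as far as these compounds go, is whether the two fluorines of compound 2 both matter, which 4-fluorophenyl would test. Also open, from the compounds shown here alone, is how a carboxylic acid or an amine on the phenyl ring at this place would read.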